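The source may hold more compounds than are shown below. What is called first, only, known or untested is meant among the compounds shown, and "the series" means these compounds.

Working notes on the biaryl amide series. Compound 1 `Cc1ccc(-c2ccc(C(=O)Nc3ccc(Oc4ccnc5[nH]ccc45)cc3)nc2)cc1` carries the methyl but no fluorine on the central ring. Compound 2 `O=C(Nc1ccc(Oc2ccnc3[nH]ccc23)c(F)c1)c1ccc(-c2ccccc2)cn1` carries the fluorine but no methyl. In a functional assay on PC-3 cells (Homo sapiens) for cytotoxicity, read by MTT assay, with a stated time of 72 h (a lower number here means a stronger inhibitor, a higher number a weaker inhibitor), compound 1 reaches only a limit, > 10000 nM. In this assay, among the measured compounds shown here, compound 2 gives 760 nM, the only number in the set. Compound 3 `Cc1ccc(-c2ccc(C(=O)Nc3ccc(Oc4ccnc5[nH]ccc45)c(F)c3)nc2)cc1` combines both features. It differs from compound 2 in one place: methyl in place of hydrogen on an aromatic carbon; cut one bond further out, the change reads phenyl to 4-methylphenyl. For the measured compounds named here, compound 1 and compound 2 differ in two places, so no step between them is counted here, and their two values can only be read side by side. The expected step in this assay is a weakening of a 6.6-fold higher number from compound 2 to compound 3 (0.82 log units; beyond the scatter), beyond the scatter. This rests on compound 1, which carries the same methyl and sits at the limit of > 10000 nM in this assay, at which 1 of the 2 values shown sits. Compound 3 is therefore estimated at 5000 nM, within a range from 1500 nM to 20000 nM, with a real chance that only a limit is reported.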

Compound 3, half-maximal inhibitory concentration: 2640 nM
The estimate for compound 3 lay 1.9-fold (0.28 log units) above the measured number; the measured number falls inside the stated range.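

With the fluoro held constant, the change from phenyl to 4-methylphenyl gives a 3.5-fold higher number from compound 2 to compound 3 (0.54 log units; beyond the scatter) in this assay, so the methyl on this aromatic carbon, para to a large group, costs a modest step and leaves a measured number on the fluoro background. Among the compounds shown here, with the methyl held constant, fluoro in place of hydrogen gives an at least 3.7-fold lower number from compound 1 to compound 3 (0.57 log units; beyond the scatter), which runs the opposite way to the methyl step and is the first sign in this set that the fluoro can recover part of what compound 1 lacks. Compound 1 is a limit and not a number, so the size of that step is only a bound: the limit of > 10000 nM in this assay, at which 1 of the 3 values shown sits.

Still open, as far as these compounds go, is whether the weakening belongs to the methyl alone or would extend to a methoxy group, a chlorine atom or an amine at the same place on that ring. Also open, from the compounds shown here alone, is the size of the fluoro step with a plain phenyl group in place of 4-methylphenyl, since only the methyl-bearing pair gives a reading for it.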